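Swapping the aryl group on an amide-type nitrogen

A few compounds are considered here, and "the series" means these few. Any claim that something is new, unique, unknown or untested is made for them only; others in the source may bear on it.

Measured in a functional assay on MCF7 cells (Homo sapiens) for antiproliferative activity, read by MTT assay; on this read-out lower numbers stand for stronger inhibition and higher numbers for weaker inhibition:
Compound 1 `COc1cc2c(Oc3ccc(NC(=O)Nc4cccc(C)c4)cc3)ccnc2cc1OCCCCCCC(=O)NO`: 1240 nM
Compound 2 `COc1cc2c(Oc3ccc(NC(=O)Nc4ccc(OC(F)(F)F)cc4)cc3)ccnc2cc1OCCCCCCC(=O)NO`: 3200 nM

Of the two measured compounds, compound 2 stands highest, at 3200 nM. Compound 3 `COc1cc2c(Oc3ccc(NC(=O)Nc4ccc(Cl)c(C(F)(F)F)c4)cc3)ccnc2cc1OCCCCCCC(=O)NO` has 4-chloro-3-(trifluoromethyl)phenyl in place of 4-(trifluoromethoxy)phenyl on an amide-type nitrogen. One measured step changes this same place, the modest 2.6-fold higher number from compound 1 to compound 2 (0.41 log units; beyond the scatter). That single step gives no direction for the new group, so no change beyond the scatter is expected in this assay. The expected change is a 1.3-fold lower number from compound 2 to compound 3 (0.12 log units; within the scatter). Compound 3 is estimated at 2400 nM, with an expected range from 900 nM to 6000 nM.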

Compound 3, half-maximal inhibitory concentration: 5150 nM
Beside the measured number, compound 3's estimate is 2.1-fold (0.33 log units) below it, within the range that was stated.
By their numbers in this assay, from the lowest: compound 1; then compounds 2 and 3 (each within the scatter of the next).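

In this assay the step reads a 1.6-fold higher number from compound 2 to compound 3 (0.21 log units; within the scatter) and so, on this amide-type nitrogen, the 4-chloro-3-(trifluoromethyl)phenyl and 4-(trifluoromethoxy)phenyl groups cannot be told apart. Set against 3-methylphenyl, the same group gives a 4.2-fold higher number from compound 1 to compound 3 (0.62 log units; beyond the scatter) and thus joins 4-(trifluoromethoxy)phenyl in a number beyond the scatter from compound 1. Nothing available accounts for this gap. The compounds shown leave open how an unsubstituted phenyl, a pyridine ring or an aryl group carrying an amine would read at this nitrogen.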